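Adding a Methyl to Compound 2

The source may report more compounds than this note shows. Statements on the series, on what has been measured and on what is new or still open speak of the compounds shown alone.

Compound 1 `Cc1nc(C)c(COc2ccccc2C(=O)O)nc1C`: 400000 nM
Compound 2 `Cc1nc(C)c(COc2ccc3ccc(=O)oc3c2)nc1C`: 1300000 nM

In a functional assay on a cell-free system (Platelet, plasma, Oryctolagus cuniculus) for inhibition, with a stated time of 5 min (a lower number here means a stronger inhibitor, a higher number a weaker inhibitor), compound 2 gives 1300000 nM, the higher of the two numbers, and the gap to compound 1 lies beyond the scatter. Compound 3 `Cc1nc(C)c(COc2ccc3c(C)cc(=O)oc3c2)nc1C` differs from compound 2 by one change, methyl in place of hydrogen on an aromatic carbon, opposite the ring oxygen. Within the data shown here, no measured pair shows the effect of such a change, so no shift beyond the scatter is expected in this assay. The expected change, a 1.3-fold lower number from compound 2 to compound 3 (0.11 log units; within the scatter), is estimated to stay within the scatter. For compound 3 the estimated value is 1000000 nM, with an expected range from 350000 nM to 2800000 nM.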

Compound 3, half-maximal inhibitory concentration: 920000 nM
Estimate against measurement, compound 3: 1.1-fold (0.04 log units) above; measured number inside the range.
By their numbers in this assay, from the lowest: compound 1; then compounds 3 and 2 (each within the scatter of the next).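

In this assay, methyl in place of hydrogen on an aromatic carbon, opposite the ring oxygen, gives a 1.4-fold lower number from compound 2 to compound 3 (0.15 log units; within the scatter) and so stays within the scatter. Among these compounds, this is the first pair to show such a change, and at this position the methyl leaves the number of compound 2 effectively unchanged. Nothing available here bears on why this is so. From the compounds shown here alone, whether an amine or a longer chain at the same position would shift the number beyond the scatter remains open. So does whether a methyl elsewhere on the shared core would do so.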